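A few compounds are considered here, and "the series" means these few. Any claim that something is new, unique, unknown or untested is made for them only; others in the source may bear on it.

Working notes on the urea series.

Compound 1 `O=C(NCCCOc1cccc(CN2CCCCC2)c1)Nc1ccccc1` gives 126 nM in an assay on isolated protein for inhibition of histamine H2 receptor (Cavia porcellus); a lower number here means tighter binding, a higher number weaker binding. Compound 2 `COc1ccc(NC(=O)NCCCOc2cccc(CN3CCCCC3)c2)c(OC)c1` gives 2240 nM, and compound 3 `O=C(NCCCOc1cccc(CN2CCCCC2)c1)Nc1ccc(C(F)(F)F)cc1` gives 1700 nM. Among the three numbers compound 3 stands second highest: its nearest neighbour is compound 2, a gap within the scatter, and its furthest is compound 1, a gap beyond it. The two steps away from the plain phenyl urea are both large, an 18-fold higher number from compound 1 to compound 2 (1.25 log units; beyond the scatter) and a 13-fold higher number from compound 1 to compound 3 (1.13 log units; beyond the scatter), while the step between the two substituted ureas is small, a 1.3-fold lower number from compound 2 to compound 3 (0.12 log units; within the scatter).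

Compound 4 `COc1ccc(OC)c(NC(=O)NCCCOc2cccc(CN3CCCCC3)c2)c1` carries the change (2,5-dimethoxyphenyl in place of 4-(trifluoromethyl)phenyl on an amide-type nitrogen). Going by the values given here, no measured step shows a 2,5-dimethoxyphenyl group. What bears on it is a 1.3-fold lower number from compound 2 to compound 3 (0.12 log units; within the scatter), which shows a 4-(trifluoromethyl)phenyl and a 2,4-dimethoxyphenyl urea sitting within the scatter of each other, and an 18-fold higher number from compound 1 to compound 2 (1.25 log units; beyond the scatter), which places a dimethoxyphenyl urea well away from compound 1. A second dimethoxyphenyl isomer is therefore expected to fall near compound 2 and compound 3, with no step beyond the scatter expected in this assay, a 1.2-fold higher number from compound 3 to compound 4 (0.07 log units; within the scatter). Compound 4 is estimated at 2000 nM, between 700 nM and 6000 nM.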

Compound 4, dissociation constant: 158 nM
For compound 4 the middle estimate is 13-fold (1.10 log units) above the measured one, and the stated range ends above it.
By their numbers in this assay, from the lowest: compounds 1 and 4 (each within the scatter of the next); then compounds 3 and 2 (each within the scatter of the next).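

In this assay the placing of the two methoxy groups on the amide-type nitrogen's phenyl matters, since exchanging the 2,4-dimethoxyphenyl for the 2,5-dimethoxyphenyl group gives a 14-fold lower number from compound 2 to compound 4 (1.15 log units; beyond the scatter) and the two isomers are not interchangeable here. The exchange of 4-(trifluoromethyl)phenyl for 2,5-dimethoxyphenyl gives an 11-fold lower number from compound 3 to compound 4 (1.03 log units; beyond the scatter) in the same direction, while the change from plain phenyl gives a 1.3-fold higher number from compound 1 to compound 4 (0.10 log units; within the scatter) and so leaves the number close to that of the unsubstituted urea. A substituted phenyl at this place is thus not tied to a higher number: compound 2 and compound 3 fit that pattern, and compound 4 goes against it.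

No measurement shown here accounts for the separation of the two dimethoxyphenyl isomers. Open, as far as these compounds go, is whether a 2,5-dichlorophenyl or a single methoxyphenyl urea would stay with compound 4 or move towards compound 2.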